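The source may report more compounds than this note shows. Statements on the series, on what has been measured and on what is new or still open speak of the compounds shown alone.

Compound 1 `Cc1ccc(S(=O)(=O)Oc2ccc3c(c2C)[C@H](Cn2cc(-c4ccccc4)nn2)[C@@]24CC(=O)[C@@](C)(CC[C@@H]32)C4)cc1` and compound 2 `C=C1C(=O)[C@]23C[C@@]1(O)CC[C@H]2c1ccc(O)c(C)c1[C@@H]3Cn1cc(-c2ccccc2)nn1` carry the same (4-phenyl-1H-1,2,3-triazol-1-yl)methyl arm on two different cores; how the two cores differ is not broken down here. Within the data shown here, in a functional assay on SW480 cells (Homo sapiens) for cytotoxicity, read by MTT assay, with a stated time of 4 days (a higher number here means a weaker inhibitor, a lower number a stronger inhibitor), compound 2 gives 260 nM, the only number in the set. Compound 1 reaches only the limit of > 20000 nM in this assay. Compound 3 `Cc1ccc(S(=O)(=O)Oc2ccc3c(c2C)[C@H](Cn2cc(-c4ccccn4)nn2)[C@@]24CC(=O)[C@@](C)(CC[C@@H]32)C4)cc1` arises from compound 1 by pyridin-2-yl in place of phenyl on an aromatic carbon. In this assay compound 3 likewise stops at the limit of > 20000 nM. The step that the two limits leave unreadable from compound 1 to compound 3 therefore cannot be sized, because the limit of > 20000 nM in this assay, at which 2 of the 3 values shown sit, hides both of its ends. Compound 4 `C=C1C(=O)[C@]23C[C@@]1(O)CC[C@H]2c1ccc(O)c(C)c1[C@@H]3Cn1cc(-c2ccccn2)nn1` stands to compound 2 as compound 3 stands to compound 1, by the same change, (pyridin-2-yl in place of phenyl on an aromatic carbon). Among the measured compounds shown here, since the one measured instance of this change gives no readable size, the expectation for compound 4 rests on compound 2, whose value of 260 nM is the only anchor in this assay. For compound 4 the step of a 1.5-fold higher number from compound 2 to compound 4 (0.19 log units; within the scatter) is expected to be small. Compound 4 is accordingly estimated at 400 nM in this assay, with a likely range from 120 nM to 1500 nM.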

Compound 4, half-maximal inhibitory concentration: 410 nM
Estimate against measurement, compound 4: 1.0-fold (0.01 log units) below, and the stated range covers the measured number.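

In this assay, among these compounds, the one readable instance of the change is a 1.6-fold higher number from compound 2 to compound 4 (0.20 log units; within the scatter) and so, on the core of compound 2, pyridin-2-yl in place of phenyl leaves the number within the usual scatter. On the core of compound 1 the same change cannot be read, because compound 1 and compound 3 both stop at a limit and not at a number: the limit of > 20000 nM in this assay, at which 2 of the 4 values shown sit. Among the compounds shown here, whether the result carries from one core to the other therefore stays untested, and the single readable pair speaks for the core of compound 2 alone.

The compounds shown leave open how the core of compound 2 responds when something other than an aromatic six-membered ring stands on the five-membered aromatic ring with 3 nitrogen, such as a carboxylic acid, an amine or a longer alkyl chain. They also leave open whether pyridin-3-yl or pyridin-4-yl would match pyridin-2-yl on that core.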